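Fluoro to trifluoromethyl on a six-membered aromatic ring

A few compounds are considered here, and "the series" means these few. Any claim that something is new, unique, unknown or untested is made for them only; others in the source may bear on it.

Of the compounds shown here, three sharing one core have been tested in a functional assay on cells (Panel colon (Carcinoma cell lines), Homo sapiens) for inhibition, read by sulforhodamine B assay, with a stated time of 48 h; on this read-out lower numbers stand for higher toxicity in this test and higher numbers for lower toxicity in this test. Compound 1 `CN1CCN(CCCOc2cccc3nc(Nc4cccc(Cl)c4)ccc23)CC1` gives 5870 nM. Compound 2 `CN1CCN(CCCOc2cccc3nc(Nc4cc(Cl)cc(Cl)c4)ccc23)CC1`, which carries chloro in place of hydrogen on an aromatic carbon, gives 6100 nM. Compound 3 `CN1CCN(CCCOc2cccc3nc(Nc4ccc(Cl)c(F)c4)ccc23)CC1` gives 6210 nM; its number is the highest of the three, yet each of its steps to the other two is within the scatter. Indeed a 1.0-fold higher number from compound 1 to compound 2 (0.02 log units; within the scatter), a 1.1-fold higher number from compound 1 to compound 3 (0.02 log units; within the scatter) and a 1.0-fold higher number from compound 2 to compound 3 (0.01 log units; within the scatter) all stayed within the scatter, so exchanging chloro and fluoro groups on this part of the molecule has not moved the read-out so far.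

Compound 4 `CN1CCN(CCCOc2cccc3nc(Nc4ccc(Cl)c(C(F)(F)F)c4)ccc23)CC1` is the next step: trifluoromethyl in place of fluoro on an aromatic carbon. Among the measured compounds shown here, no measured step involves trifluoromethyl, so the only guide is that the earlier chloro and fluoro changes stayed flat. Compound 4 is therefore expected to stay level, with a 1.0-fold lower number from compound 3 to compound 4 (0.01 log units; within the scatter) within the scatter. The estimate for compound 4 in this assay is 6000 nM, between 3000 nM and 12000 nM.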

Compound 4, concentration lethal to 50% of the cells: 6270 nM
The estimate for compound 4 lay 1.0-fold (0.02 log units) below the measured number, and the stated range covers the measured number.
By their numbers in this assay, from the lowest: compounds 1, 2, 3 and 4 (each within the scatter of the next).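

Replacing fluoro with trifluoromethyl takes the group at this position, ortho to a chloro group, from one heavy atom to four, yet the read-out in this assay stays level (a 1.0-fold higher number from compound 3 to compound 4 (0.00 log units; within the scatter)). The earlier exchanges involved only chloro and fluoro groups, whereas this result shows that a clearly larger group at this position also leaves the number within the scatter, and compound 4 likewise stays within the scatter of the other two (a 1.0-fold higher number from compound 2 to compound 4 (0.01 log units; within the scatter); a 1.1-fold higher number from compound 1 to compound 4 (0.03 log units; within the scatter)). No measurement shown here offers an explanation for this flat result.

All four compounds carry only chloro, fluoro or trifluoromethyl groups on this ring. As far as these compounds go, whether an amine, a carboxylic acid or a longer carbon chain at this position would shift the number remains open.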